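The source may hold more compounds than are shown below. What is called first, only, known or untested is meant among the compounds shown, and "the series" means these compounds.

Of the compounds shown here, two have been measured so far. Compound 1 `Fc1cccc(-c2nc(Nc3ccccc3)c3cc(F)ccc3n2)c1` gives 48300 nM in a functional assay on HL-60 cells (Homo sapiens) for cytotoxicity, read by MTT assay, with a stated time of 48 h; a lower number here means a stronger inhibitor, a higher number a weaker inhibitor. Compound 2 `COc1ccc(Nc2nc(-c3cccc(F)c3)nc3ccc(F)cc23)cc1` carries a methoxy group in place of hydrogen on an aromatic carbon, and in this assay compound 2 gives 38600 nM. The step of a 1.3-fold lower number from compound 1 to compound 2 (0.10 log units; within the scatter) is too small to count as a real difference, so compound 2 and compound 1 stand within the scatter of each other, with no ranking between them.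

Compound 3 `COc1ccccc1Nc1nc(-c2cccc(F)c2)nc2ccc(F)cc12` is the next compound to be tested. It differs from compound 2 in one place: 2-methoxyphenyl in place of 4-methoxyphenyl on a nitrogen on an aromatic ring. Among the compounds with values here, the single step measured so far, replacing hydrogen with methoxy on an aromatic carbon, does not show what happens when the methoxy group sits elsewhere on the same ring; no measured step addresses this rearrangement directly. Within the data shown here, the only guide is that introducing the methoxy group itself changed little. For compound 3 the expectation in this assay is therefore a number close to that of compound 2, with no step beyond the scatter. Compound 3 is estimated at 40000 nM, within a range from 15000 nM to 110000 nM. For compound 3 this means an expected step of a 1.0-fold higher number from compound 2 to compound 3 (0.02 log units; within the scatter).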

Compound 3, half-maximal inhibitory concentration: > 50000 nM
Compound 3 ended at the assay's limit (the forecaster's own chance of this, stated with the estimate: 15%); middle value at least 1.2-fold (0.09 log units) from the limit.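

In this assay compound 3 gives > 50000 nM, which is a limit of the assay and not a number. Exchanging 4-methoxyphenyl for 2-methoxyphenyl on the nitrogen gives an at least 1.2-fold higher number from compound 2 to compound 3 (0.11 log units; that floor lies within the scatter), and placing the methoxy group in the 2-methoxyphenyl arrangement on the unsubstituted phenyl of compound 1 gives an at least 1.0-fold higher number from compound 1 to compound 3 (0.01 log units; that floor lies within the scatter). Unlike the step between the two earlier compounds, these steps are floors rather than full sizes, so moving the methoxy group on this ring brings no lower number, while the true size of any rise remains unknown: the limit of > 50000 nM in this assay, at which 1 of the 3 values shown sits.

The compounds shown leave open whether compound 3 lies just past the limit or far past it, and so whether the place of the methoxy group on this ring truly matters in this assay. As far as these compounds go, it also remains open whether a different group on this phenyl ring, such as an amine or a carboxylic acid, could bring the number clearly below those of compound 1 and compound 2.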